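The compounds below may be only part of what the source reports. "The series", "measured", "known", "first", "only" and "open" are said of these compounds alone.

Compounds measured in a functional assay on the whole organism (strain Wistar albino) for inhibition, with Rattus norvegicus as the target, read by paw edema, with stated times of 1 h and 2 h, at a dose of 0.32 mmol/kg by the intraperitoneal route; on this read-out higher numbers stand for more inhibition at the one dose given (going by the name of the read-out) and lower numbers for less inhibition:
- compound 1, `Cc1ccc(-c2nn(-c3ccc(Cl)cc3)cc2C=O)cc1`: 49.9%
- compound 2, `Cc1ccc(-c2nn(-c3ccc(Cl)cc3)cc2/C=N\c2ccccc2)cc1`: 40.1%
- compound 3, `COc1ccc(/N=C\c2cn(-c3ccc(Cl)cc3)nc2-c2ccc(C)cc2)cc1`: 62%

Compound 3 stands highest of the three numbers in this assay; compound 1 is nearest to it, and compound 2 is furthest, both gaps lying beyond the scatter. The step from compound 1 to compound 2 is a number 9.8 percentage points lower from compound 1 to compound 2 (within the scatter), while the step from compound 2 to compound 3 is a number 21.9 percentage points higher from compound 2 to compound 3 (beyond the scatter).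

Compound 4, `Cc1ccc(-c2nn(-c3ccc(Cl)cc3)cc2/C=N\c2ccc(Cl)cc2)cc1`, has not yet been measured. It differs from compound 3 in one place: chloro in place of methoxy on an aromatic carbon. The change sits on an aromatic carbon of a six-membered aromatic ring of carbon only, para to a large group.

For the measured compounds named here, only one measured step touches this position, the one from compound 2 to compound 3, and it shows that adding methoxy there raised the read-out by a modest amount. Going by the values given here, no measured step tells what chloro does there. The expectation for compound 4 therefore rests on compound 2, which gives 40.1% with hydrogen in this place, and on compound 3, which gives 62% with methoxy. Compound 4 is expected to lie between those two, so the estimated step is a number 10 percentage points lower from compound 3 to compound 4 (within the scatter). Compound 4 is thus estimated at 52%, in a range from 36% to 68%.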

Compound 4, a percentage reported as inhibition, in the whole organism at one dose (the size of the read-out at that dose, not a potency): 48.3%
Beside the measured number, compound 4's estimate is 3.7 percentage points above it; measured number inside the range.
By their numbers in this assay, from the lowest: compounds 2, 4 and 1 (each within the scatter of the next); then compound 3.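

In this assay, the result shows that what methoxy did at this place on the aromatic ring does not carry over to chloro: there is a number 13.7 percentage points lower from compound 3 to compound 4 (beyond the scatter), and against the unsubstituted ring there is a number 8.2 percentage points higher from compound 2 to compound 4 (within the scatter), so chloro cannot be told apart from hydrogen here, whereas methoxy could. The chloro-bearing group also cannot be told apart from the small carbonyl group it replaces on the shared core, with a number 1.6 percentage points lower from compound 1 to compound 4 (within the scatter), so among compounds 1, 2 and 4 neither change gives a difference beyond the scatter, and compound 3 alone stands clear of compound 2 and compound 4. Nothing measured here explains why methoxy and chloro part ways at this place.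

Going by these compounds, it remains open whether the gain belongs to methoxy alone or would also appear with a hydroxyl, an amine or a longer chain such as ethoxy at the same place. On these data alone, it is also open whether methoxy would give the same result on another carbon of this ring, or with the carbonyl-derived link to the core replaced by an amide.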